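This account rests on a few compounds, and the source may have more. Where it says the series, first, only, none or still open, it means among the compounds named here.

Measured compounds:
- compound 1, `CCCSc1nc(N/N=C/c2ccc(C)cc2)c2nnn(Cc3ccccc3)c2n1`, in a functional assay on MGC-803 cells (Homo sapiens) for antiproliferative activity, read by MTT assay, with a stated time of 72 h (on this read-out lower numbers stand for stronger inhibition and higher numbers for weaker inhibition), gives a result that is only a limit, > 64000 nM.
- compound 2, `CCCSc1nc(N/N=C(\C)c2ccccc2O)c2nnn(Cc3ccccc3Cl)c2n1`, gives 35000 nM in this assay.
- compound 3, `CCCSc1nc(N/N=C(\C)c2ccccc2O)c2nnn(Cc3ccc(F)cc3)c2n1`, gives 11000 nM in this assay.

Within the data shown here, compound 1 therefore does not stand on a number at all: it sits at the limit of > 64000 nM in this assay, at which 1 of the 3 values shown sits, and no measured step starts from it. The unmeasured compound 4, `CCCSc1nc(N/N=C/c2c(O)ccc3ccccc23)c2nnn(Cc3ccccc3)c2n1`, differs from compound 1 only at the carbon bearing the double bond to nitrogen, where (2-hydroxynaphthalen-1-yl in place of 4-methylphenyl on a carbon with a double bond to nitrogen).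

Among the measured compounds shown here, the one measured step, a 3.2-fold lower number from compound 2 to compound 3 (0.50 log units; beyond the scatter), concerns a change at the saturated chain carbon bound to an aromatic nitrogen, not the aryl group on the carbon double-bonded to nitrogen, so it does not bear directly on the change from compound 1 to compound 4. Compounds 2 and 3, whose aryl group on that carbon carries a hydroxyl, both return measurable values, whereas compound 1, whose aryl group carries none, does not; this is the only hint available, from two compounds that also differ elsewhere.

On that slender basis compound 4 is expected to move from the limit into the measurable range, with a step of an at least 3.2-fold lower number from compound 1 to compound 4 (0.50 log units; beyond the scatter) in this assay. The estimate for compound 4 is 20000 nM, within 5000 nM to 80000 nM.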

Compound 4, half-maximal inhibitory concentration: 3710 nM
Beside the measured number, compound 4's estimate is 5.4-fold (0.73 log units) above it; measured number outside the range, below it.
By their numbers in this assay, from the lowest: compound 4; then compound 3; then compound 2. At a limit, above all of these: compound 1.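

The change from 4-methylphenyl to 2-hydroxynaphthalen-1-yl gives an at least 17-fold lower number from compound 1 to compound 4 (1.23 log units; beyond the scatter) in this assay, and this is the only step shown at the carbon with a double bond to nitrogen. It shows directly that the group at this place can take a compound from the limit into the measurable range, which compounds 2 and 3 could only hint at since they differ from compound 1 elsewhere as well. Compound 1 remains a limit, so the step's true size is unknown: the limit of > 64000 nM in this assay, at which 1 of the 4 values shown sits.

The change brings in a second aromatic ring and a hydroxyl together, so the compounds shown cannot assign the step to either one. From the compounds shown here alone, whether a plain naphthalen-1-yl, or a methoxy group in place of the hydroxyl, would keep the lower number remains open.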